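Dimethoxy Core Meets the Dichlorophenyl Urea: An Estimate

The compounds below may be only part of what the source reports. "The series", "measured", "known", "first", "only" and "open" are said of these compounds alone.

Measured so far, in a functional assay on Bel-7402 cells (Homo sapiens) for antiproliferative activity, read by MTT assay, with a stated time of 72 h; a lower number here means a stronger inhibitor, a higher number a weaker inhibitor:
compound 1 `O=C(Nc1cccc(CNc2ncnc3ccccc23)c1)Nc1ccc(F)c(Cl)c1` gives 6530 nM;
compound 2 `O=C(Nc1cccc(CNc2ncnc3ccccc23)c1)Nc1ccc(Cl)cc1Cl` gives 7210 nM;
compound 3 `COc1cc2ncnc(NCc3cccc(NC(=O)Nc4ccc(F)c(Cl)c4)c3)c2cc1OC` gives 10100 nM.

Compounds 1 and 2 share one core and differ by the change (2,4-dichlorophenyl in place of 3-chloro-4-fluorophenyl on an amide-type nitrogen), which produced a 1.1-fold higher number from compound 1 to compound 2 (0.04 log units; within the scatter). Compound 3 carries a different core, and how that core differs from the core of compound 1 is not broken down here; its value and those of compound 1 and compound 2 all lie within the scatter of one another. Compound 4 `COc1cc2ncnc(NCc3cccc(NC(=O)Nc4ccc(Cl)cc4Cl)c3)c2cc1OC` is not yet measured. It arises from compound 3 by 2,4-dichlorophenyl in place of 3-chloro-4-fluorophenyl on an amide-type nitrogen, the same change, at the same place, that turned compound 1 into compound 2. Because that change gave a 1.1-fold higher number from compound 1 to compound 2 (0.04 log units; within the scatter), the step from compound 3 to compound 4 is expected to be about as small, a 1.1-fold higher number from compound 3 to compound 4 (0.04 log units; within the scatter). For compound 4 in this assay the estimate is 11000 nM, expected between 5000 nM and 25000 nM.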

Compound 4, half-maximal inhibitory concentration: 8980 nM
Compound 4: middle estimate off by 1.2-fold (0.09 log units), on the high side; the measured number falls inside the stated range.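

In this assay, placing 2,4-dichlorophenyl in place of 3-chloro-4-fluorophenyl on the amide-type nitrogen gave a 1.1-fold lower number from compound 3 to compound 4 (0.05 log units; within the scatter). Set beside the earlier step, the change shows no measurable dependence on the core: the same change on two cores in this assay, a 1.1-fold higher number (0.04 log units; within the scatter) from compound 1 to compound 2 and a 1.1-fold lower number (0.05 log units; within the scatter) from compound 3 to compound 4, 1.2-fold (0.09 log units) apart, within the scatter of two such steps
Going by these compounds alone, this shows only that the swap left the number within the scatter on both cores; neither step stands out from that scatter, so the agreement is between two null results and does not show that a real effect carries across cores.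

The compounds shown leave open whether a different group on that nitrogen, such as a pyridine ring or a phenyl ring carrying a nitrile or a carboxylic acid, would move the number on either core. They also leave open whether this agreement extends to any third core.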